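From 2,4-dichlorophenyl to 3-nitrophenyl on the shared core

The compounds below may be only part of what the source reports. "The series", "measured", "known", "first", "only" and "open" are said of these compounds alone.

Measured in a functional assay on MCF7 cells (Homo sapiens) for cytotoxicity, read by MTT assay, with a stated time of 72 h; on this read-out higher numbers stand for weaker inhibition and lower numbers for stronger inhibition:
Compound 1 (`CNC(=O)c1cc(Oc2ccc(C(=O)/C=C/c3ccco3)cc2)ccn1`) "not determined" (no result reported)
Compound 2 (`CNC(=O)c1cc(Oc2ccc(C(=O)/C=C/c3ccc(F)cc3Cl)cc2)ccn1`) 21100 nM
Compound 3 (`CNC(=O)c1cc(Oc2ccc(C(=O)/C=C/c3ccc(Cl)cc3Cl)cc2)ccn1`) 3990 nM

Compound 3 holds the lower of the two numbers available, and compound 1 offers no number for comparison. Still to be measured is compound 4 (`CNC(=O)c1cc(Oc2ccc(C(=O)/C=C/c3cccc([N+](=O)[O-])c3)cc2)ccn1`), which carries 3-nitrophenyl in place of 2,4-dichlorophenyl on a double-bonded chain carbon bound to a double-bonded chain carbon. Among the measured compounds shown here, only one measured step bears on this, and only in part: a 5.3-fold lower number from compound 2 to compound 3 (0.72 log units; beyond the scatter), with chloro in place of fluoro on an aromatic carbon. That step is modest but beyond the scatter. For the measured compounds named here, the change to compound 4 replaces the whole group, and no compound carrying 3-nitrophenyl has a value yet, so the guide is loose. Compound 3 at 3990 nM is the lower of the pair and compound 2 at 21100 nM the higher, so a moderate rise into the span between them is expected in this assay. The expected step is a 2.5-fold higher number from compound 3 to compound 4 (0.40 log units; beyond the scatter). The estimated value for compound 4 is 10000 nM, with an expected range from 3000 nM to 35000 nM.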

Compound 4, half-maximal inhibitory concentration: > 50000 nM
Compound 4: a limit, no number; the forecaster's own chance of this, stated with the estimate: 10%; at least 5.0-fold (0.69 log units) between middle value and limit.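

Compound 4 reaches a limit of this assay, not a number: the limit of > 50000 nM in this assay, at which 1 of the 4 values shown sits. Replacing the whole 2,4-dichlorophenyl group with 3-nitrophenyl on a double-bonded chain carbon bound to a double-bonded chain carbon gives an at least 12-fold higher number from compound 3 to compound 4 (1.09 log units; beyond the scatter), a large step, where the swap of fluoro for chloro had been modest. The comparison with the other halogen-bearing compound gives an at least 2.3-fold higher number from compound 2 to compound 4 (0.37 log units; beyond the scatter), so compound 4 lies outside the span of the two halogen-bearing compounds rather than inside it.

The compounds shown leave open whether the rise follows the arrival of the nitro group or the departure of the two chlorines, as both change in the one step. An amine or a methoxy group in place of the nitro group would bear on that question.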